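A few compounds are considered here, and "the series" means these few. Any claim that something is new, unique, unknown or untested is made for them only; others in the source may bear on it.

The assay throughout is a functional assay on MDA-MB-468 cells (Homo sapiens) for cytotoxicity, read by resazurin assay, with a stated time of 72 h; a higher number here means a weaker inhibitor, a lower number a stronger inhibitor. The compounds with values so far:

compound 1, `OCCCSC(=S)NCc1cccnc1`: 6610 nM
compound 2, `CCCCOC(=O)CCSC(=S)NCc1cccnc1`: 12800 nM
compound 3, `O=C(CCSC(=S)NCc1cccnc1)NCc1ccccc1`: > 100000 nM, a limit of this assay rather than a number

All three share the same core, a dithiocarbamate carrying a pyridinylmethyl group on nitrogen, and differ only in the chain attached to the sulfur. Compound 1, with a hydroxypropyl chain, gives the lowest of the two real numbers, but its value and that of compound 2 lie within the usual scatter of each other, so no ranking between them can be drawn. Compound 3 sits at the limit of > 100000 nM in this assay, at which 1 of the 3 values shown sits.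

The next compound, compound 4 `O=S(=O)(O)CCCSC(=S)NCc1cccnc1`, keeps the chain length of compound 1 and changes one group: sulfo in place of hydroxy on a saturated chain carbon, three bonds along the chain from a sulfur. Among the compounds with values here, no step between two measured compounds with a change of this kind has been recorded, so the expectation rests on the three values alone and on the change itself. Compound 4 is expected to come out somewhat weaker in this assay, a step from compound 1 to compound 4 of about a 4.5-fold higher number from compound 1 to compound 4 (0.66 log units; beyond the scatter). The estimate for compound 4 is 30000 nM, with a range of 8000 nM to 150000 nM, and a real chance that only a limit is reported.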

Compound 4, half-maximal inhibitory concentration: 11100 nM
Beside the measured number, compound 4's estimate is 2.7-fold (0.43 log units) above it, within the range that was stated.
By their numbers in this assay, from the lowest: compounds 1, 4 and 2 (each within the scatter of the next). At a limit, above all of these: compound 3.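

In this assay, putting sulfo in place of hydroxy on a saturated chain carbon, three bonds along the chain from a sulfur, gives a step that stays within the usual scatter (a 1.7-fold higher number from compound 1 to compound 4 (0.23 log units; within the scatter)), so the two compounds cannot be told apart. Within the data shown here, this is the first single change at this place with a readable size, and it shows that a group of 4 heavy atoms can enter where 1 heavy atom leaves without the number moving beyond the scatter. No measurement shown here bears on why these two groups read alike in this assay.

A carboxylic acid, an amine or a methyl ether at this same place would show whether the result holds for other groups or is particular to hydroxy and sulfo. Among these compounds, a shorter or a longer chain carrying sulfo would show whether the distance from the sulfur matters, since this single pair tests only one chain length.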